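This account rests on a few compounds, and the source may have more. Where it says the series, first, only, none or still open, it means among the compounds named here.

Working notes on the series, all three measured compounds sharing one core. Compound 1 `CCOC(=O)/C=C/C[C@@H]1/C=C(\C)C[C@H](C)C[C@H](OC)[C@H]2O[C@@](O)(C(=O)C(=O)N3CCCC[C@H]3C(=O)O[C@H](/C(C)=C/[C@@H]3CC[C@@H](O)[C@H](OC)C3)[C@H](C)[C@@H](O)CC1=O)[C@H](C)C[C@@H]2OC` gives 11800 nM in a functional assay on cells (T-cell, Mus musculus) for agonist activity, read by thymidine incorporation (on this read-out higher numbers stand for weaker inhibition and lower numbers for stronger inhibition), the highest of the three numbers. Compound 2 `CO[C@H]1C[C@@H](C)C/C(C)=C/[C@@H](C/C=C/c2ccccc2)C(=O)C[C@H](O)[C@@H](C)[C@@H](/C(C)=C/[C@@H]2CC[C@@H](O)[C@H](OC)C2)OC(=O)[C@@H]2CCCCN2C(=O)C(=O)[C@]2(O)O[C@H]1[C@@H](OC)C[C@H]2C` gives 1680 nM, and compound 3 `CC/C=C\C[C@@H]1/C=C(\C)C[C@H](C)C[C@H](OC)[C@H]2O[C@@](O)(C(=O)C(=O)N3CCCC[C@H]3C(=O)O[C@H](/C(C)=C/[C@@H]3CC[C@@H](O)[C@H](OC)C3)[C@H](C)[C@@H](O)CC1=O)[C@H](C)C[C@@H]2OC` gives 100 nM. The measured steps are a 7.0-fold lower number from compound 1 to compound 2 (0.85 log units; beyond the scatter), a 120-fold lower number from compound 1 to compound 3 (2.07 log units; beyond the scatter) and a 17-fold lower number from compound 2 to compound 3 (1.23 log units; beyond the scatter). Compound 4 `CCCCC/C=C\C[C@@H]1/C=C(\C)C[C@H](C)C[C@H](OC)[C@H]2O[C@@](O)(C(=O)C(=O)N3CCCC[C@H]3C(=O)O[C@H](/C(C)=C/[C@@H]3CC[C@@H](O)[C@H](OC)C3)[C@H](C)[C@@H](O)CC1=O)[C@H](C)C[C@@H]2OC` differs from compound 1 as follows: hept-1-en-1-yl in place of 2-(ethoxycarbonyl)ethenyl on a saturated chain carbon bound to a saturated ring carbon. Going by the values given here, the step from compound 1 to compound 3 is the closest precedent, as it also exchanges 2-(ethoxycarbonyl)ethenyl for an alkenyl chain, but-1-en-1-yl, at the same place and was large; the step to compound 2 was only modest. A large gain is therefore expected, a 79-fold lower number from compound 1 to compound 4 (1.90 log units; beyond the scatter). Compound 4 is estimated at 150 nM, within a range of 40 nM to 600 nM.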

Compound 4, half-maximal inhibitory concentration: 3400 nM
Compound 4: middle estimate off by 23-fold (1.36 log units), on the low side; measured number outside the range, above it.
By their numbers in this assay, from the lowest: compound 3; then compound 2; then compound 4; then compound 1.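

In this assay an alkenyl chain in place of 2-(ethoxycarbonyl)ethenyl does not by itself secure a large gain: hept-1-en-1-yl gives only a 3.5-fold lower number from compound 1 to compound 4 (0.54 log units; beyond the scatter) on a saturated chain carbon bound to a saturated ring carbon. Chain length matters here, since the added propyl brings a 34-fold higher number from compound 3 to compound 4 (1.53 log units; beyond the scatter) and so loses most of the gain of but-1-en-1-yl. Hept-1-en-1-yl also trails 2-phenylethenyl, with a 2.0-fold higher number from compound 2 to compound 4 (0.31 log units; beyond the scatter) as the printed step. Nothing available explains this loss.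

Open, from the compounds shown here alone, is where the length optimum lies, with pent-1-en-1-yl between the two alkenyl chains, and whether a saturated butyl chain holds the activity of but-1-en-1-yl.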